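This account rests on a few compounds, and the source may have more. Where it says the series, first, only, none or still open, it means among the compounds named here.

In a functional assay on A549 cells (Homo sapiens) for antiproliferative activity, read by MTT assay (on this read-out lower numbers stand for stronger inhibition and higher numbers for weaker inhibition), compound 1 `COc1cc2c(Oc3ccc(NC(=O)Nc4ccccc4Cl)cc3)ccnc2cc1OCCCCCCC(=O)NO` gives 1910 nM, compound 2 `COc1cc2c(Oc3ccc(NC(=O)Nc4cccc(C)c4)cc3)ccnc2cc1OCCCCCCC(=O)NO` gives 2010 nM and compound 3 `COc1cc2c(Oc3ccc(NC(=O)N/N=C/c4ccccc4)cc3)ccnc2cc1OCCCCCCC(=O)NO` gives 3700 nM. Compound 3 therefore cannot be told apart from the other two. Compound 4 `COc1cc2c(Oc3ccc(NC(=O)NNC(=O)c4ccccc4)cc3)ccnc2cc1OCCCCCCC(=O)NO` alters the group on the amide-type nitrogen of compound 3, bringing in benzamido: a group of 9 heavy atoms (7 carbon, 1 nitrogen, 1 oxygen; one six-membered aromatic ring of carbon only) in place of a group of 8 heavy atoms (7 carbon, 1 nitrogen; one six-membered aromatic ring of carbon only), on an amide-type nitrogen. The most relevant measured changes fall at this same nitrogen: a 1.9-fold higher number from compound 1 to compound 3 (0.29 log units; within the scatter), a 1.8-fold higher number from compound 2 to compound 3 (0.27 log units; within the scatter) and a 1.1-fold higher number from compound 1 to compound 2 (0.02 log units; within the scatter). All of them stay within the scatter, so no step beyond the scatter is expected in this assay, and no direction can be favoured with confidence. The expected change is a 1.2-fold lower number from compound 3 to compound 4 (0.09 log units; within the scatter). For compound 4 the estimated value is 3000 nM, with an expected range from 1300 nM to 7000 nM.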

Compound 4, half-maximal inhibitory concentration: 2820 nM
For compound 4 the middle estimate is 1.1-fold (0.03 log units) above the measured one; the measured number falls inside the stated range.
By their numbers in this assay, from the lowest: compounds 1, 2, 4 and 3 (each within the scatter of the next).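

In this assay benzamido on the amide-type nitrogen brings in a hydrogen-bond donor that the leaving group lacks, yet the result is only a 1.3-fold lower number from compound 3 to compound 4 (0.12 log units; within the scatter) and stays within the scatter. The comparisons with the simpler aryl groups also stay within the scatter, with a 1.4-fold higher number from compound 2 to compound 4 (0.15 log units; within the scatter) and a 1.5-fold higher number from compound 1 to compound 4 (0.17 log units; within the scatter) as the two steps. This nitrogen has now carried four different groups with no step beyond the scatter, and no measurement at hand offers a reason for this. From the compounds shown here alone, whether an amine, a carboxylic acid or a longer chain on this nitrogen would move the number beyond the scatter remains open.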